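From Cyclopropyl to Trifluoromethylphenyl on the Shared Core

A few compounds are considered here, and "the series" means these few. Any claim that something is new, unique, unknown or untested is made for them only; others in the source may bear on it.

Three measured compounds share one core. Compound 1 `Cc1ccc(-c2nnn(CC(=O)Nc3cc(C)nn3C3CCCCC3)n2)cc1` carries a 4-methylphenyl, compound 2 `Cc1cccc(-c2nnn(CC(=O)Nc3cc(C)nn3C3CCCCC3)n2)c1` a 3-methylphenyl, and compound 3 `Cc1cc(NC(=O)Cn2nnc(C3CC3)n2)n(C2CCCCC2)n1` a cyclopropyl on the same aromatic carbon. In an assay on HEK293 cells for activation of Kir3.1/Kir3.2 (Homo sapiens), read by thallium flux (a lower number here means a smaller maximal response, a higher number a larger maximal response), compound 1 gives 86%, and compound 2 gives 93%, the move being a number 7 percentage points higher from compound 1 to compound 2 (within the scatter). For compound 3 the read-out is a limit of the assay, > 68%, and compound 3 therefore stands at that limit rather than at a number (the limit of > 68% in this assay, at which 1 of the 3 values shown sits). Compound 4 `Cc1cc(NC(=O)Cn2nnc(-c3ccc(C(F)(F)F)cc3)n2)n(C2CCCCC2)n1` differs from compound 3 in one place: 4-(trifluoromethyl)phenyl in place of cyclopropyl on an aromatic carbon. The measured steps that touch this position are a step that the limit leaves unreadable from compound 1 to compound 3 and a step that the limit leaves unreadable from compound 2 to compound 3, and neither can be sized. What remains is that compounds 1 and 2, each bearing a substituted phenyl on that carbon, sit within the scatter of each other in this assay, and compound 4 again carries a substituted phenyl there. Compound 4 is therefore expected to give 88% in this assay, between 70% and 100%. The expected step that the limit leaves unreadable from compound 3 to compound 4 is read against a starting value that is itself only a limit.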

Compound 4, largest response reached (Emax), in percent of the reference or control that the assay uses: 94%
Estimate against measurement, compound 4: 6 percentage points below; the range from low to high includes it.
By their numbers in this assay, from the lowest: compounds 1, 2 and 4 (each within the scatter of the next).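

Replacing a methylphenyl with 4-(trifluoromethyl)phenyl on this aromatic carbon leaves this assay within the scatter, with a number 1 percentage points higher from compound 2 to compound 4 (within the scatter) and a number 8 percentage points higher from compound 1 to compound 4 (within the scatter) on record. The earlier pair showed only that moving a methyl on the phenyl changed nothing readable, whereas compounds 1, 2 and 4 now show that this position also holds a phenyl bearing trifluoromethyl in place of methyl with no readable change, and none of the three goes against this. Compound 3 stands at a limit of the assay, > 68%, so every step from its cyclopropyl to a substituted phenyl remains unreadable: the limit of > 68% in this assay, at which 1 of the 4 values shown sits.

Going by these compounds, it stays open how a cyclopropyl compares with these phenyl groups as a number. The compounds shown also leave open whether a carboxylic acid or an amine on that phenyl would keep the response within the same scatter.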